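Swapping the Aryl Group on a Shared Triazole Acetamide Core

The source may hold more compounds than are shown below. What is called first, only, known or untested is meant among the compounds shown, and "the series" means these compounds.

Measured compounds:
- Compound 1, `CCOC(=O)c1sc(NC(=O)Cn2cc(-c3ccc(OC)cc3)nn2)nc1C`, gives 2330 nM in a functional assay on BMDM cells (Mus musculus, strain C57BL/6) for inhibition, with a stated time of 2 days; on this read-out higher numbers stand for weaker inhibition and lower numbers for stronger inhibition.
- Compound 2, `CCOC(=O)c1sc(NC(=O)Cn2cc(-c3ccncc3)nn2)nc1C`, gives 120 nM in this assay.

Compound 2 holds the lowest number of the two measured compounds, and the gap to compound 1 is large: a 19-fold lower number from compound 1 to compound 2 (1.29 log units; beyond the scatter). Among the measured compounds shown here, the only change in that step is the exchange of one aromatic group on the shared core, so the aromatic group attached to the five-membered ring matters a great deal here.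

Compound 3, `CCOC(=O)c1sc(NC(=O)Cn2cc(-c3ccc(C#N)cc3)nn2)nc1C`, carries a third option at that position. Its difference from compound 2 is 4-cyanophenyl in place of pyridin-4-yl on an aromatic carbon. For the measured compounds named here, no measured step covers this exact exchange. Going by the values given here, the one step that bears on it, a 19-fold lower number from compound 1 to compound 2 (1.29 log units; beyond the scatter), shows that the choice of this group can move the number a great deal, with 4-methoxyphenyl far weaker than pyridin-4-yl. 4-Cyanophenyl is a new group, so the expected position is uncertain, and the estimate is placed between the two measured compounds but closer to compound 2. The expected step is a 3.3-fold higher number from compound 2 to compound 3 (0.52 log units; beyond the scatter). For compound 3 the estimate in this assay is 400 nM, with a range from 100 nM to 1600 nM.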

Compound 3, half-maximal inhibitory concentration: 310 nM
Compound 3: the middle estimate sits 1.3-fold (0.11 log units) above what was measured, and the stated range covers the measured number.
By their numbers in this assay, from the lowest: compound 2; then compound 3; then compound 1.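

Compound 3 shows that this position can give a much lower number without a nitrogen in the aromatic ring. In this assay there is a 7.5-fold lower number from compound 1 to compound 3 (0.88 log units; beyond the scatter), a change confined to the group carried on the same carbon-only ring, so what sits on that ring matters as well as the kind of ring. Pyridin-4-yl still holds the lowest number of the three, with a 2.6-fold higher number from compound 2 to compound 3 (0.41 log units; beyond the scatter), and no measurement here explains this order or the larger gain from the nitrile.

On these data alone, it remains open how an amine or a carboxylic acid in place of the nitrile on the same ring would compare, and whether a longer chain ending in a nitrile would keep the gain over 4-methoxyphenyl. All three compounds also share the same ethyl ester on the core, so it is equally unknown whether their order would hold if that ester were replaced by an amide or a carboxylic acid.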